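The source may hold more compounds than are shown below. What is called first, only, known or untested is meant among the compounds shown, and "the series" means these compounds.

Measured so far in a functional assay on SW-620 cells (Homo sapiens) for antiproliferative activity, read by MTT assay, with a stated time of 72 h; a lower number here means a stronger inhibitor, a higher number a weaker inhibitor:
compound 1 `O=C1O[C@H]([C@@H](O)Cn2cc(-c3cc(F)cc(F)c3)nn2)C(OCc2ccccc2)=C1OCc1ccccc1` — > 100000 nM
compound 2 `O=C1O/C(=C\Cn2cc(-c3cc(C(F)(F)F)cc(C(F)(F)F)c3)nn2)C(OCc2ccccc2)=C1OCc1ccccc1` — > 100000 nM

Compound 1 stands only at a limit in this assay: > 100000 nM is the edge of the measurement, not a number. Compound 2 likewise reaches only a limit in this assay, > 100000 nM. Among the measured compounds shown here, both readings sit on (the limit of > 100000 nM in this assay, at which 2 of the 2 values shown sit), and no step between measured compounds exists, so nothing yet shows how a change at the five-membered aromatic ring moves potency.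

Compound 3 `CCCCCCCCCCc1cn(C[C@H](O)[C@H]2OC(=O)C(OCc3ccccc3)=C2OCc2ccccc2)nn1` is the next candidate for this assay. It differs from compound 1 in one place: decyl in place of 3,5-difluorophenyl on an aromatic carbon. The expected step is an at least 2.0-fold lower number from compound 1 to compound 3 (0.30 log units; that floor lies within the scatter), toward a weak but measurable inhibition, with a second limit remaining roughly as likely as a number. Compound 3 is estimated at 50000 nM in this assay, within a range from 8000 nM to 200000 nM.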

Compound 3, half-maximal inhibitory concentration: 45200 nM
For compound 3 the middle estimate is 1.1-fold (0.04 log units) above the measured one; the measured number falls inside the stated range.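

In this assay, the aromatic carbon of the five-membered aromatic ring with 3 nitrogen proves able to move the read-out: decyl in place of 3,5-difluorophenyl gives an at least 2.2-fold lower number from compound 1 to compound 3 (0.34 log units; beyond the scatter). Going by these compounds, compound 1 stands at > 100000 nM, which is a limit and not a number, so this step has only a floor and its full size stays unknown. Compound 3 shows that a substituent with no ring at this position can give a measurable value, though most of the series still rests on a limit: the limit of > 100000 nM in this assay, at which 2 of the 3 values shown sit.

On these data alone, whether the measurable value depends on the length of the chain remains open, as a hexyl or a longer chain at the same carbon would show. Also open, as far as these compounds go, is how an amine or a carboxylic acid at the end of the decyl chain would move the read-out.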